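The source may report more compounds than this note shows. Statements on the series, on what has been measured and on what is new or still open speak of the compounds shown alone.

Measured compounds:
compound 1 `C=CC(=O)Nc1cccc(-n2c(-c3nc(-c4cnn(C5CCN(C)CC5)c4)cnc3N)nc3ccccc32)c1`, 120 mL.min-1.g-1
compound 2 `C=CC(=O)Nc1cccc(-n2c(-c3nc(-c4cnn(C)c4)cnc3N)nc3ccccc32)c1`, 24 mL.min-1.g-1
compound 3 `C=CC(=O)Nc1cccc(-n2c(-c3nc(-c4cnn(C5CCN(C(C)C)CC5)c4)cnc3N)nc3ccccc32)c1`, 37 mL.min-1.g-1

In an ADME assay on liver for metabolic stability, with Liver microsome (Homo sapiens) as the target, using microsomes (a higher number here means faster removal of the compound, a lower number slower removal), compound 3 gives the second highest of the three numbers: it sits near compound 2, with a gap of a 1.5-fold higher number from compound 2 to compound 3 (0.19 log units; within the scatter), and further from compound 1, from which it is separated by a 3.2-fold lower number from compound 1 to compound 3 (0.51 log units; beyond the scatter). Compound 4 `C=CC(=O)Nc1cccc(-n2c(-c3nc(-c4cnn(C5CCN(C(=O)CO)CC5)c4)cnc3N)nc3ccccc32)c1` differs from compound 3 only at the amine nitrogen in the six-membered non-aromatic ring with one nitrogen: (hydroxymethyl)carbonyl in place of isopropyl on an amine nitrogen in a ring. Going by the values given here, the measured steps that touch that nitrogen or that ring are a 3.2-fold lower number from compound 1 to compound 3 (0.51 log units; beyond the scatter) and, one bond further out, a 5.0-fold lower number from compound 1 to compound 2 (0.70 log units; beyond the scatter) and a 1.5-fold higher number from compound 2 to compound 3 (0.19 log units; within the scatter); none of them exchanges isopropyl for a (hydroxymethyl)carbonyl group, so no step of the present kind has been measured. All three steps were modest or within the scatter, which suggests that compound 4 is expected to stay in the same neighbourhood, with a 1.2-fold lower number from compound 3 to compound 4 (0.09 log units; within the scatter) being the most likely outcome in this assay, the direction uncertain. Compound 4 is therefore estimated at 30 mL.min-1.g-1, between 12 mL.min-1.g-1 and 75 mL.min-1.g-1.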

Compound 4, intrinsic clearance in microsomes: > 300 mL.min-1.g-1
Compound 4 was reported as a limit; the forecaster's own chance of this, stated with the estimate: 5%; at least 10-fold (1.00 log units) between middle value and limit.
By their numbers in this assay, from the lowest: compounds 2 and 3 (each within the scatter of the next); then compound 1. At a limit, above all of these: compound 4.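

Compound 4 is reported only as a limit, so each of its steps is a bound: the limit of > 300 mL.min-1.g-1 in this assay, at which 1 of the 4 values shown sits. In this assay, the amine nitrogen in the ring proves sensitive to what it carries: (hydroxymethyl)carbonyl in place of isopropyl gives an at least 8.1-fold higher number from compound 3 to compound 4 (0.90 log units; beyond the scatter), while isopropyl in place of methyl at that nitrogen gave a 3.2-fold lower number from compound 1 to compound 3 (0.51 log units; beyond the scatter) in the opposite direction. The same group also separates the compound from the two other earlier compounds, with an at least 2.5-fold higher number from compound 1 to compound 4 (0.39 log units; beyond the scatter) and an at least 12-fold higher number from compound 2 to compound 4 (1.09 log units; beyond the scatter), so it does not stay with compound 2 as isopropyl does.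

The compounds shown leave open whether the rise follows the carbonyl on the nitrogen or the hydroxyl at its end, a question that an acetyl group or a 2-hydroxyethyl chain at the same nitrogen would address. As far as these compounds go, the true size of the steps to compound 4 also stays open.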